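Trifluoromethyl for fluoro at the far end of compound 1

A few compounds are considered here, and "the series" means these few. Any claim that something is new, unique, unknown or untested is made for them only; others in the source may bear on it.

Compound 1, `O=C(O)c1cc(-c2ccc(-c3ccc(F)cc3)cc2)n(-c2ccc(Cl)cc2Cl)n1`, gives 41300 nM in an assay on isolated protein for inhibition of methionine--tRNA ligase, cytoplasmic (Homo sapiens); a lower number here means a stronger inhibitor, a higher number a weaker inhibitor. Compound 2, `O=C(O)c1cc(-c2ccc(-c3ccc(Cl)cc3Cl)cc2)n(Cc2cccnc2)n1`, gives only a limit of the assay in this assay, namely > 100000 nM. Compound 3, `O=C(O)c1cc(-c2ccc(-c3ccc(Cl)cc3Cl)cc2)n(CCO)n1`, likewise gives only a limit in this assay, namely > 100000 nM.

Going by the values given here, compound 1 thus stands as the only real number among the three; the other two values sit at the limit of > 100000 nM in this assay, at which 2 of the 3 values shown sit. Among the compounds with values here, the one step between measured neighbours, a step that the two limits leave unreadable from compound 2 to compound 3, cannot be read for size, and it concerns the group on the aromatic nitrogen, not the outer ring that changes here.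

Compound 4, `O=C(O)c1cc(-c2ccc(-c3ccc(C(F)(F)F)cc3)cc2)n(-c2ccc(Cl)cc2Cl)n1`, differs from compound 1 by trifluoromethyl in place of fluoro on an aromatic carbon. Within the data shown here, no measured step touches this position, so nothing in the data argues for a move in either direction, and the expected step from compound 1 is a 1.2-fold lower number from compound 1 to compound 4 (0.07 log units; within the scatter), within the scatter. Compound 4 is therefore estimated at 35000 nM in this assay, with a range from 9000 nM to 100000 nM.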

Compound 4, half-maximal inhibitory concentration: 33500 nM
The estimate for compound 4 lay 1.0-fold (0.02 log units) above the measured number; low and high end bracket the measured number.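

In this assay, going by these compounds alone, the change at this position gives the first step that can be read for size: a 1.2-fold lower number from compound 1 to compound 4 (0.09 log units; within the scatter). On this aromatic carbon, para to a large group, trifluoromethyl with its 4 heavy atoms therefore stands in place of fluoro with its 1 heavy atom, and the two compounds cannot be told apart. The position thus accepts the larger group with no step beyond the scatter, but nothing shown bears on why that is so.

Going by these compounds, whether an amine, a methoxy group or a nitrile at this same place would give a step beyond the scatter remains open. Also open, on these data alone, is whether the change from 4-fluorophenyl to 4-(trifluoromethyl)phenyl would give the same step with a different group on the aromatic nitrogen.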